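This account rests on a few compounds, and the source may have more. Where it says the series, first, only, none or still open, it means among the compounds named here.

Within the data shown here, in a functional assay on PC-3 cells (Homo sapiens) for cytotoxicity, read by MTT assay, with a stated time of 48 h (on this read-out higher numbers stand for weaker inhibition and lower numbers for stronger inhibition), compound 3 `COc1cc(-n2c(-c3ccc(F)cc3F)cn(C(C)=O)c2=O)cc(OC)c1OC` gives 34300 nM, the only actual number among the compounds measured so far. Compound 1 `COc1ccc(-c2c[nH]c(=O)n2-c2cc(OC)c(OC)c(OC)c2)cc1OC` is reported only as a limit, > 50000 nM. Compound 2 `COc1cc(-n2c(-c3ccccc3)cn(C(C)=O)c2=O)cc(OC)c1OC` is also reported only as a limit, > 50000 nM. The comparison therefore rests on very little, with the limit of > 50000 nM in this assay, at which 2 of the 3 values shown sit.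

Compound 4 `COc1ccc(-c2cn(C(C)=O)c(=O)n2-c2cc(OC)c(OC)c(OC)c2)cc1OC` has not yet been measured. It differs from compound 3 at a single place, an aromatic carbon of the five-membered ring, where 3,4-dimethoxyphenyl stands in place of 2,4-difluorophenyl: 3,4-dimethoxyphenyl in place of 2,4-difluorophenyl on an aromatic carbon.

Among the measured compounds shown here, because an at least 1.4-fold lower number from compound 2 to compound 3 (0.16 log units; that floor lies within the scatter) is the only measured step at this place and stays within the scatter, no step beyond the scatter is expected in this assay, in either direction. The estimated change is a 1.2-fold higher number from compound 3 to compound 4 (0.07 log units; within the scatter), which would leave the two compounds indistinguishable. For compound 4 the expected value is 40000 nM, with an estimated range from 15000 nM to 60000 nM.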

Compound 4, half-maximal inhibitory concentration: > 50000 nM
Compound 4 was reported as a limit; the forecaster's own chance of this, stated with the estimate: 50%; middle value at least 1.2-fold (0.09 log units) from the limit.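

In this assay, the 3,4-dimethoxyphenyl group on this aromatic carbon of the five-membered ring gives an at least 1.4-fold higher number from compound 3 to compound 4 (0.16 log units; that floor lies within the scatter), so this change shows no gain over 2,4-difluorophenyl, though the size of the step cannot be told apart from the scatter. Among these compounds, with phenyl and 3,4-dimethoxyphenyl both ending at a limit, compound 3 remains the only compound with an actual number, and the two hydrogen-bond acceptors that enter with the new group bring no readable value. The steps to compound 4 from compound 2 and from compound 1 cannot be read, so the acetyl on the ring nitrogen gains no measured effect here.

The compounds shown leave open whether an amine or a carboxylic acid on the phenyl ring at this place would give a readable number. Little can be compared at this position so far: the limit of > 50000 nM in this assay, at which 3 of the 4 values shown sit.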